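Replacing the hydroxy on the amide nitrogen with pyrimidin-2-yl

This account rests on a few compounds, and the source may have more. Where it says the series, first, only, none or still open, it means among the compounds named here.

Measured compounds:
- Compound 1, `Cc1ccc(OCC(=O)N(Cc2cccs2)c2ccccn2)cc1`, gives 200 nM in an assay on HEK293 cells for agonist activity at transient receptor potential cation channel subfamily M member 8 (Homo sapiens), read by fluorescence and calcium flux, with a stated time of 15 min; on this read-out higher numbers stand for an effect only at larger amounts of compound and lower numbers for an effect already at smaller amounts.
- Compound 2, `Cc1ccc(OCC(=O)N(Cc2cccs2)C(C)(C)C)cc1`, gives 11000 nM in this assay.
- Compound 3, `Cc1ccc(OCC(=O)N(O)Cc2cccs2)cc1`, gives 8000 nM in this assay.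

All three share the same core and differ only in the group on the amide-type nitrogen. Compound 3 holds the second highest of the three numbers. Its nearest neighbour is compound 2, and a 1.4-fold lower number from compound 2 to compound 3 (0.14 log units; within the scatter), so these two cannot be told apart. The furthest is compound 1, with a 40-fold higher number from compound 1 to compound 3 (1.60 log units; beyond the scatter).

Compound 4, `Cc1ccc(OCC(=O)N(Cc2cccs2)c2ncccn2)cc1`, has not been measured. It differs from compound 3 in one place: pyrimidin-2-yl in place of hydroxy on an amide-type nitrogen.

Among the compounds with values here, two measured steps bear on this. Swapping pyridin-2-yl for a small group gave a large rise in number: a 55-fold higher number from compound 1 to compound 2 (1.74 log units; beyond the scatter) and a 40-fold higher number from compound 1 to compound 3 (1.60 log units; beyond the scatter). Compound 4 reverses that kind of change, since pyrimidin-2-yl resembles the pyridin-2-yl of compound 1. A large step downward, well beyond the scatter, is therefore expected in this assay for compound 4, roughly undoing the change seen from compound 1 to compound 3, though not necessarily all of it.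

For compound 4 the estimate in this assay is 400 nM, with a range from 100 nM to 2500 nM, corresponding to an expected step of a 20-fold lower number from compound 3 to compound 4 (1.30 log units; beyond the scatter).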

Compound 4, half-maximal effective concentration: 3700 nM
Beside the measured number, compound 4's estimate is 9.3-fold (0.97 log units) below it; measured number outside the range, above it.
By their numbers in this assay, from the lowest: compound 1; then compound 4; then compounds 3 and 2 (each within the scatter of the next).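

The earlier compounds shown here left open whether any six-membered aromatic ring on the amide-type nitrogen would be enough for a low number in this assay, and compound 4 shows that it is not. Pyrimidin-2-yl does bring a modest gain over the two non-ring groups, with a 2.2-fold lower number from compound 3 to compound 4 (0.33 log units; beyond the scatter) and a 3.0-fold lower number from compound 2 to compound 4 (0.47 log units; beyond the scatter), yet it stays far from pyridin-2-yl, as a 19-fold higher number from compound 1 to compound 4 (1.27 log units; beyond the scatter) makes clear. At this position, then, the identity of the ring counts and not just the presence of one, although no information at hand explains the gap between these two closely related rings.

The compounds shown do not reveal how the number would respond to phenyl, a six-membered aromatic ring of carbon atoms alone, which would help show whether the ring nitrogen of pyridin-2-yl is needed at all. Pyridin-3-yl and pyrazin-2-yl also remain open, and they would test whether the placement of the ring nitrogens matters as much as their number.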